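This account rests on a few compounds, and the source may have more. Where it says the series, first, only, none or still open, it means among the compounds named here.

Among the compounds with values here, compound 1 `O=C(Nc1cccc(-c2oc3cc(-c4ccc(F)cc4)ccc3c(=O)c2O)c1)c1ccc(F)cc1` gives 9280 nM in a functional assay on HepG2 cells (Homo sapiens) for antiproliferative activity, read by CCK-8 assay, with a stated time of 72 h (a lower number here means a stronger inhibitor, a higher number a weaker inhibitor), the highest of the two numbers known, though its nearest neighbour sits within the scatter. That neighbour, compound 2 `COc1ccc(C(=O)Nc2cccc(-c3oc4cc(-c5ccc(F)cc5)ccc4c(=O)c3O)c2)cc1`, gives 8420 nM in this assay. Within the data shown here, the only measured step, a 1.1-fold lower number from compound 1 to compound 2 (0.04 log units; within the scatter), swaps a methoxy for a fluoro and does not touch the position changed here. Compound 3 `O=C(Nc1cccc(-c2oc3cc(-c4ccc(F)cc4)ccc3c(=O)c2O)c1)c1ccc(F)cc1F` differs from compound 1 by fluoro in place of hydrogen on an aromatic carbon. Among the measured compounds shown here, with no measured step bearing directly on this change, the step of a 1.0-fold lower number from compound 1 to compound 3 (0.01 log units; within the scatter) is expected to stay within the scatter. Compound 3 is therefore estimated at 9000 nM, ranging from 3000 nM to 27000 nM.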

Compound 3, half-maximal inhibitory concentration: 26400 nM
The estimate for compound 3 lay 2.9-fold (0.47 log units) below the measured number, within the range that was stated.
By their numbers in this assay, from the lowest: compounds 2 and 1 (each within the scatter of the next); then compound 3.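

Within the data shown here, putting a second fluoro on the ring, which turns 4-fluorophenyl into 2,4-difluorophenyl, is the first change here to move the number in this assay beyond the scatter (a 2.8-fold higher number from compound 1 to compound 3 (0.45 log units; beyond the scatter)). Replacing the 4-methoxyphenyl group with the same 2,4-difluorophenyl group gives a similar result (a 3.1-fold higher number from compound 2 to compound 3 (0.50 log units; beyond the scatter)), so this single added atom on the carbon ortho to a large group matters, and it weakens the compound. No measurement shown explains the rise. On these data alone, whether a chloro, a methyl or an amine on that same carbon would also raise the number stays open. So does whether a fluoro on another carbon of this ring would do the same.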